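This account rests on a few compounds, and the source may have more. Where it says the series, first, only, none or still open, it means among the compounds named here.

Series in a physicochemical assay for solubility, in phosphate buffer, with a stated time of 18 h, at pH 7.4; a lower number here means a less soluble compound, a higher number a more soluble compound:
- compound 1 `COc1cc2ncnc(-n3nc(-c4ccccn4)nc3N)c2cc1[N+](=O)[O-]`: 2000 nM
- compound 2 `COc1cc2ncnc(-n3nc(-c4ccccn4)nc3N)c2cc1N`: 3000 nM

Among the measured compounds shown here, compound 1 stands level with compound 2, the only other measured compound, as the two values lie within the scatter of each other. Compound 3 `Nc1nc(-c2ccccn2)nn1-c1ncnc2cc(N3CCNCC3)c([N+](=O)[O-])cc12` is the next to be read in this assay. It carries piperazin-1-yl in place of methoxy on an aromatic carbon, with piperazin-1-yl in place of methoxy, ortho to a nitro group. For the measured compounds named here, the one measured step, a 1.5-fold higher number from compound 1 to compound 2 (0.18 log units; within the scatter), changes the nitro group and leaves the methoxy untouched, so it offers only weak guidance. A modest upward step is expected, held loosely. The expected step is a 2.5-fold higher number from compound 1 to compound 3 (0.40 log units; beyond the scatter). For compound 3 the estimate is 5000 nM, with an expected range of 1500 nM to 30000 nM.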

Compound 3, solubility: 4000 nM
Compound 3: the middle estimate sits 1.3-fold (0.10 log units) above what was measured; the range from low to high includes it.
By their numbers in this assay, from the lowest: compounds 1, 2 and 3 (each within the scatter of the next).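

In this assay piperazin-1-yl in place of methoxy, ortho to a nitro group, gives a 2.0-fold higher number from compound 1 to compound 3 (0.30 log units; within the scatter) and is the first change shown at this position. The position therefore carries a six-membered non-aromatic ring with 2 hetero atoms without a difference beyond the scatter, which the earlier step at the nitro group could not show. No separate measurement bears on this result.
As far as these compounds go, whether morpholin-4-yl or an open-chain dimethylamino group would read alike here remains open. So does whether piperazin-1-yl would read alike with amino in place of nitro.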